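A Cinnamoyl Amide in Place of a Nitrobenzoyl Group

The compounds below may be only part of what the source reports. "The series", "measured", "known", "first", "only" and "open" are said of these compounds alone.

Compound 1 `O=C(Nc1cc(Sc2ncn[nH]2)c(O)c2ccccc12)c1cccc([N+](=O)[O-])c1`: 48000 nM
Compound 2 `O=C(Nc1cc(Sc2nncs2)c(O)c2ccccc12)c1ccc(Cl)cc1`: a limit only, > 100000 nM

Among the measured compounds shown here, in a functional assay on MDA-MB-231 cells (Homo sapiens) for antiproliferative activity, read by MTT assay, with a stated time of 48 h (a lower number here means a stronger inhibitor, a higher number a weaker inhibitor), compound 1 gives 48000 nM, the only true number among the two values shown. Compound 2 reaches only the limit of this assay, > 100000 nM (the limit of > 100000 nM in this assay, at which 1 of the 2 values shown sits). Compound 3 `O=C(/C=C/c1ccc(Cl)cc1)Nc1cc(Sc2ncn[nH]2)c(O)c2ccccc12` differs from compound 1 at one place: 2-(4-chlorophenyl)ethenyl in place of 3-nitrophenyl on a carbonyl carbon. For the measured compounds named here, no measured step between compounds is available to size this change, so compound 3 is expected to stay near compound 1, with an estimated step of a 1.4-fold lower number from compound 1 to compound 3 (0.14 log units; within the scatter) not beyond the usual scatter. Compound 3 is estimated at 35000 nM, within 12000 nM to 100000 nM.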

Compound 3, half-maximal inhibitory concentration: > 100000 nM
Compound 3: a limit, no number; the forecaster's own chance of this, stated with the estimate: 25%; middle value at least 2.8-fold (0.45 log units) from the limit.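

In this assay, the group on the carbonyl carbon proves not to be freely exchangeable: 2-(4-chlorophenyl)ethenyl in place of 3-nitrophenyl gives an at least 2.0-fold higher number from compound 1 to compound 3 (0.31 log units; beyond the scatter). Compound 3 gives > 100000 nM, which is a limit and not a number, so this step is a bound and its full size cannot be read. Compound 1 remains the only compound shown with a true number, and the others stand at the limit: the limit of > 100000 nM in this assay, at which 2 of the 3 values shown sit.

Still open, on these data alone, is whether a carboxylic acid, an amine or a short alkyl chain on this carbonyl carbon would give a measurable value.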